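The source may hold more compounds than are shown below. What is called first, only, known or untested is meant among the compounds shown, and "the series" means these compounds.

Of the compounds shown here, two sharing one core have been measured in a functional assay for inhibition of nuclear factor NF-kappa-B complex (Homo sapiens); a higher number here means a weaker inhibitor, a lower number a stronger inhibitor. Compound 1, `COc1ccc2c(c1)OC(c1cc(OC)c(OC)c(OC)c1)C(C(=O)N1CCCCC1)=C2`, gives > 50000 nM in this assay, which is a limit of the assay and not a number. Among the measured compounds shown here, compound 2, `COc1ccc2c(c1)OC(c1cc(OC)c(OC)c(OC)c1)C(C(=O)OCCc1ccccc1)=C2`, gives 16200 nM in this assay, and this is the only number among the values shown. For the measured compounds named here, the step between them, an at least 3.0-fold lower number from compound 1 to compound 2 (0.48 log units; beyond the scatter), is the single measured step, and it shows that the group on the carbonyl carbon can move the read-out beyond the scatter. Compound 1 sits at the limit of > 50000 nM in this assay, at which 1 of the 2 values shown sits.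

Compound 3, `COc1ccc2c(c1)OC(c1cc(OC)c(OC)c(OC)c1)C(C(=O)O)=C2`, remains to be measured. It differs from compound 2 by hydrogen in place of phenethyl on an oxygen next to a carbonyl group. Going by the values given here, the only step that bears on it is the one from compound 1 to compound 2, which altered the same carbonyl substituent; it was at least modest in size, yet it gives no direction that carries over to replacing phenethyl with hydrogen. The step of a 2.5-fold higher number from compound 2 to compound 3 (0.39 log units; beyond the scatter) is therefore estimated with wide uncertainty. Compound 3 is expected to give about 40000 nM in this assay, within a range from 10000 nM to 150000 nM.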

Compound 3, half-maximal inhibitory concentration: > 50000 nM
Compound 3: only a limit was reported; the forecaster's own chance of this, stated with the estimate: 45%; middle value at least 1.2-fold (0.09 log units) from the limit.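

Replacing phenethyl with hydrogen on the oxygen next to a carbonyl group gives an at least 3.0-fold higher number from compound 2 to compound 3 (0.48 log units; beyond the scatter) in this assay, so this position has now been changed with the phenethyloxy group as the starting point, and the loss of that group alone moves the read-out beyond the scatter. Compound 3 gives > 50000 nM, which is a limit of the assay and not a number. Both departures from phenethyloxy on the carbonyl carbon, to piperidin-1-yl and to hydroxy, therefore end at the same reported limit, leaving compound 2 as the only one of the three with a number: the limit of > 50000 nM in this assay, at which 2 of the 3 values shown sit.

From the compounds shown here alone, the step between compound 1 and compound 3 cannot be read, and how far either compound lies from compound 2 stays open beyond the printed limits. Also open, going by these compounds, is which part of the phenethyloxy group carries the difference, a question that a methyl ester, a benzyl ester or a phenethyl amide on the same carbonyl carbon could address.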